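A few compounds are considered here, and "the series" means these few. Any claim that something is new, unique, unknown or untested is made for them only; others in the source may bear on it.

Compound 1 `O=[N+]([O-])c1c[nH]c(-c2nnc(Cc3ccc(F)c4ccccc34)o2)c1` gives 229000 nM.
Compound 2 `Cn1cc([N+](=O)[O-])cc1-c1nnc(Cc2ccc(F)c3ccccc23)o1` gives 119000 nM.
Compound 3 `Cn1cc([N+](=O)[O-])cc1-c1nnc(-c2cc(-c3ccccc3)nc3ccc(Cl)cc23)o1` gives 328000 nM.

All three were read in an ADME assay on Vero cells (Chlorocebus sabaeus) for cytotoxicity, read by MTT assay, with a stated time of 72 h; on this read-out higher numbers stand for weaker inhibition and lower numbers for stronger inhibition. Compound 2 and compound 1 share a core and differ by hydrogen in place of methyl on an aromatic nitrogen, a change that gave a 1.9-fold higher number from compound 2 to compound 1 (0.28 log units; within the scatter). Compound 3 carries another core; the difference between the two cores is not broken down here. Compound 3 shows the highest of the three numbers, its gap to compound 1 within the scatter and its gap to compound 2 beyond it.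

Compound 4 `O=[N+]([O-])c1c[nH]c(-c2nnc(-c3cc(-c4ccccc4)nc4ccc(Cl)cc34)o2)c1` has not yet been measured in this assay. It stands to compound 3 as compound 1 stands to compound 2: the change is hydrogen in place of methyl on an aromatic nitrogen, the same change as before. Resting on a 1.9-fold higher number from compound 2 to compound 1 (0.28 log units; within the scatter), which fell within the scatter, the expected step is a 1.7-fold higher number from compound 3 to compound 4 (0.22 log units; within the scatter). Compound 4 is therefore expected to give about 550000 nM, most likely between 300000 nM and 1000000 nM.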

Compound 4, half-maximal inhibitory concentration: 281000 nM
Beside the measured number, compound 4's estimate is 2.0-fold (0.29 log units) above it; measured number below the stated range.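

On the core of compound 3, hydrogen in place of methyl on an aromatic nitrogen gave a 1.2-fold lower number from compound 3 to compound 4 (0.07 log units; within the scatter) in this assay, so on neither core does this change shift the number beyond the scatter. Set side by side, the two steps cannot be told apart: the same change on two cores in this assay, a 1.9-fold higher number (0.28 log units; within the scatter) from compound 2 to compound 1 and a 1.2-fold lower number (0.07 log units; within the scatter) from compound 3 to compound 4, 2.2-fold (0.35 log units) apart, within the scatter of two such steps. This shows that the change carried over between these two cores without a detectable difference, but it does not establish a size or direction for the step, and two cores say nothing about others in the series.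

The compounds shown leave open how a longer chain on that nitrogen would read in this assay. They also leave open what an amine in place of the nitro group would give.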